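Swapping Methoxy for Dimethylamino in a Urea Series

The source may hold more compounds than are shown below. What is called first, only, known or untested is meant among the compounds shown, and "the series" means these compounds.

Three compounds built on one shared core were tested in an ADME assay on HEK293 cells (Homo sapiens) for cytotoxicity, with a stated time of 72 h; a lower number here means that less compound is needed, a higher number that more compound is needed for the effect. Compound 1 has the structure `COc1ccc(NC(=O)Nc2cc(C)nc3ccccc23)cc1`. In this assay compound 1 reaches only the limit of the assay, > 25000 nM, and no number. Compound 2, with the structure `COc1ccc(NC(=O)Nc2cc(C)nc3ccccc23)cc1F`, likewise gives only the limit > 25000 nM in this assay. Compound 3, with the structure `Cc1cc(NC(=O)Nc2cc(Cl)cc(Cl)c2)c2ccccc2n1`, also gives only the limit > 25000 nM. The single step that joins two of these compounds, a step that the two limits leave unreadable from compound 1 to compound 2, cannot be given a size because the limit of > 25000 nM in this assay, at which 3 of the 3 values shown sit, holds every value shown.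

Compound 4, with the structure `Cc1cc(NC(=O)Nc2ccc(N(C)C)cc2)c2ccccc2n1`, is not yet measured and differs from compound 1 by dimethylamino in place of methoxy on an aromatic carbon. The change puts dimethylamino in place of methoxy on an aromatic carbon, para to a large group. Among the compounds with values here, since every measured value rests at the limit, no measured step bears on this change with a readable size, and no step beyond the scatter is expected in either direction. Compound 4 is therefore expected to give about 30000 nM in this assay, estimated within a range from 12000 nM to 100000 nM. The implied step, a step that the limit leaves unreadable from compound 1 to compound 4, is expected to stay within the scatter.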

Compound 4, half-maximal effective concentration: > 25000 nM
Compound 4 ended at the assay's limit; the forecaster's own chance of this, stated with the estimate: 85%; the middle value is on the limit's open side.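

Compound 4, like compound 1, gives only a limit and no number, so the change from methoxy to dimethylamino cannot be given a size, because all the values rest at the same limit: the limit of > 25000 nM in this assay, at which 4 of the 4 values shown sit. Still open, from the compounds shown here alone, is whether these two groups differ at all in this assay, and what concentration any of the four compounds would actually need.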